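Isoxazole-linked coumarin ethers: chloro to nitro on the pendant phenyl

A few compounds are considered here, and "the series" means these few. Any claim that something is new, unique, unknown or untested is made for them only; others in the source may bear on it.

Measured compounds:
compound 1 `O=c1ccc2cc(OCc3cc(-c4cccc(Cl)c4)no3)ccc2o1` — 42100 nM
compound 2 `O=c1ccc2cc(OCc3cc(-c4ccc(Cl)cc4)no3)ccc2o1` — 55800 nM

Both were tested in a functional assay on HCT-116 cells (Homo sapiens) for cytotoxicity, read by MTT assay, with a stated time of 48 h; a lower number here means a stronger inhibitor, a higher number a weaker inhibitor. Compound 2 has the highest of the two numbers, but a 1.3-fold higher number from compound 1 to compound 2 (0.12 log units; within the scatter), so the two cannot be told apart. Compound 3 `O=c1ccc2cc(OCc3cc(-c4cccc([N+](=O)[O-])c4)no3)ccc2o1` differs from compound 2 in one place: 3-nitrophenyl in place of 4-chlorophenyl on an aromatic carbon. For the measured compounds named here, no measured step covers a chloro-to-nitro swap; the only step seen, a 1.3-fold higher number from compound 1 to compound 2 (0.12 log units; within the scatter), bears solely on the ring position of the chlorine. Compound 3 is therefore expected to stay near compound 2, with a 1.2-fold lower number from compound 2 to compound 3 (0.07 log units; within the scatter). The estimate for compound 3 is 48000 nM, within 16000 nM to 150000 nM.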

Compound 3, half-maximal inhibitory concentration: 48200 nM
Estimate against measurement, compound 3: 1.0-fold (0.00 log units) below, within the range that was stated.
By their numbers in this assay, from the lowest: compounds 1, 3 and 2 (each within the scatter of the next).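

In this assay, the earlier step bore only on where the chlorine sits, whereas these steps change the group itself: 3-nitrophenyl in place of 4-chlorophenyl gives a 1.2-fold lower number from compound 2 to compound 3 (0.06 log units; within the scatter) and nitro in place of chloro gives a 1.1-fold higher number from compound 1 to compound 3 (0.06 log units; within the scatter) and neither step leaves the scatter. On these three compounds, the pendant phenyl therefore takes chloro or nitro with no change that can be read. Nothing measured here offers an explanation for this. The compounds shown leave open whether an amine or a carboxylic acid on that phenyl would give a step beyond the scatter.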